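Two analogues at the assay limit and a chlorinated third

This account rests on a few compounds, and the source may have more. Where it says the series, first, only, none or still open, it means among the compounds named here.

Compound 1 `Cc1ccc(Cn2cc(CSc3nc(Nc4ccccc4C)c(C#N)c(-c4ccccc4)n3)nn2)cc1`: > 64000 nM
Compound 2 `Cc1ccc(Cn2cc(CSc3nc(Nc4ccc(C)cc4)c(C#N)c(-c4ccccc4)n3)nn2)cc1`: > 64000 nM

In a functional assay on MCF7 cells (Homo sapiens) for inhibition, read by MTT assay, with a stated time of 72 h (a lower number here means a stronger inhibitor, a higher number a weaker inhibitor), compound 1 gives > 64000 nM, which is a limit of the assay and not a number. Compound 2 also reaches only a limit in this assay, > 64000 nM. The step that the two limits leave unreadable from compound 1 to compound 2 therefore cannot be read, because both values sit at the limit of > 64000 nM in this assay, at which 2 of the 2 values shown sit. Compound 2 thus stands at the limit, and no number places it anywhere within the measured range.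

Compound 3 `Cc1ccc(Cn2cc(CSc3nc(Nc4ccccc4Cl)c(C#N)c(-c4ccccc4)n3)nn2)cc1` is the next variant: 2-chlorophenyl in place of 4-methylphenyl on a nitrogen on an aromatic ring. Among the compounds with values here, the only measured step that bears on this change is the one from compound 1 to compound 2, whose size is not readable, so nothing measured speaks for or against a shift in this assay. Compound 1, which carries a 2-methylphenyl on the same nitrogen, also shows only a limit. The step expected from compound 2 to compound 3 in this assay is a step that the limit leaves unreadable from compound 2 to compound 3. For compound 3 the estimated value in this assay is 100000 nM, with a range from 30000 nM to 400000 nM, and a limit rather than a number is expected to be the most likely outcome.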

Compound 3, half-maximal inhibitory concentration: 34400 nM
For compound 3 the middle estimate is 2.9-fold (0.46 log units) above the measured one; measured number inside the range.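

In this assay compound 3 is the only one of the three to return a number rather than a limit, which shows that a change to the aryl group on this nitrogen can bring the reading within the measured range. Replacing 4-methylphenyl with 2-chlorophenyl gives an at least 1.8-fold lower number from compound 2 to compound 3 (0.26 log units; that floor lies within the scatter), and chloro in place of methyl on the aromatic carbon gives an at least 1.8-fold lower number from compound 1 to compound 3 (0.26 log units; that floor lies within the scatter). Both steps are floors and their full size stays unknown, since the reading for the partner compound in each pair is a limit: the limit of > 64000 nM in this assay, at which 2 of the 3 values shown sit.

The compounds shown leave open whether a 4-chlorophenyl on the same nitrogen would also give a number in this assay, which would help to separate the effect of the chloro group from that of where it sits on the ring. They also leave open how a 2-methoxyphenyl or a 2-bromophenyl would read at this position, and whether an amine in place of the nitrile on the shared core would move the number at all.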